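Three compounds level, and a piperazine amide to come

The source may hold more compounds than are shown below. What is called first, only, known or untested is meant among the compounds shown, and "the series" means these compounds.

Measured in a functional assay on the whole organism for inhibition, with Cavia porcellus as the target; a higher number here means that more compound is needed for the effect, a lower number that less compound is needed:
- compound 1 `COc1ccccc1OCC1SCCN1C(=O)C[S+](C)[O-]`: 25 mg/kg
- compound 2 `COc1ccccc1OCC1SCCN1C(=O)CC(C)=O`: 30 mg/kg
- compound 3 `COc1ccccc1OCC1SCCN1C(=O)CC(=O)O`: 20 mg/kg

Compound 3 cannot be told apart from the other two. For the measured compounds named here, the steps that bear on it are small: a 1.3-fold lower number from compound 1 to compound 3 (0.10 log units; within the scatter), and a 1.5-fold lower number from compound 2 to compound 3 (0.18 log units; within the scatter). The second changes the same carbonyl carbon that changes next.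

Compound 4 `COc1ccccc1OCC1SCCN1C(=O)CC(=O)N1CCN(C)CC1` carries 4-methylpiperazin-1-yl in place of hydroxy on a carbonyl carbon. Going by the values given here, no measured compound carries a group of this kind, so the range must stay wide. Still, every swap so far stayed within the scatter, so no real shift is expected. The estimated step is a 1.3-fold higher number from compound 3 to compound 4 (0.10 log units; within the scatter). For compound 4 the expected value is 25 mg/kg, with an estimated range from 10 mg/kg to 70 mg/kg.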

Compound 4, dose for half-maximal effect: 27 mg/kg
For compound 4 the middle estimate is 1.1-fold (0.03 log units) below the measured one, within the range that was stated.
By their numbers in this assay, from the lowest: compounds 3, 1, 4 and 2 (each within the scatter of the next).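

On this carbonyl carbon, the much larger ring-bearing 4-methylpiperazin-1-yl can replace hydroxy in this assay with a step that stays inside the noise: a 1.4-fold higher number from compound 3 to compound 4 (0.13 log units; within the scatter). Set against methyl the step is a 1.1-fold lower number from compound 2 to compound 4 (0.05 log units; within the scatter), and set against the sulfur-bearing group on the saturated chain carbon it is a 1.1-fold higher number from compound 1 to compound 4 (0.03 log units; within the scatter), so even this jump in size leaves all four compounds level, and no measurement on hand says why. Still open, on these data alone, is whether a phenyl ring or a primary amine on a longer chain at this carbonyl carbon would move the number beyond the scatter.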